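This account rests on a few compounds, and the source may have more. Where it says the series, first, only, none or still open, it means among the compounds named here.

Measured compounds:
- compound 1 `COc1cc(C(=O)N2CCc3ccccc32)cc(C#N)c1O`: in an assay on tissue (RPTEC cells) for inhibition of solute carrier family 22 member 12 (Homo sapiens), read by scintillation counting, with stated times of 15 min and 2 h (on this read-out higher numbers stand for weaker inhibition and lower numbers for stronger inhibition), compound 1 gives > 100000 nM, which is a limit of the assay and not a number.
- compound 2 `N#Cc1cc(C(=O)N2CS(=O)(=O)c3ccccc32)cc(Cl)c1O`: in this assay compound 2 gives > 100000 nM, which is a limit of the assay and not a number.

Compound 2 stands at the limit of > 100000 nM in this assay, at which 2 of the 2 values shown sit, so no number for it is known. Among the measured compounds shown here, compound 1 sits at the same limit, and no step between measured compounds can be drawn from these two values. Compound 3 `C#Cc1cc(C(=O)N2CS(=O)(=O)c3ccccc32)cc(C#N)c1O` differs from compound 2 in one place: ethynyl in place of chloro on an aromatic carbon. Nothing measured shows what ethynyl in place of chloro does in this assay. With both measured compounds at the limit, the expectation for compound 3 is that it too stays weak, and the estimated step of a number no higher from compound 2 to compound 3 (the limit leaves the size open) is none beyond the scatter. Compound 3 is expected to give 100000 nM, within 30000 nM to 300000 nM, most likely reported again only as a limit.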

Compound 3, half-maximal inhibitory concentration: 3200 nM
Estimate against measurement, compound 3: 31-fold (1.49 log units) above; measured number below the stated range.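

In this assay, ethynyl in place of chloro on an aromatic carbon, ortho to a hydroxy group and meta to a cyano group, gives an at least 31-fold lower number from compound 2 to compound 3 (1.49 log units; beyond the scatter). This position is therefore not silent: with the rest of compound 2 unchanged, this single exchange is enough to give a measurable number, the first in the series. Compound 2 is held at a limit and not a number, so the full size of the step remains unknown: the limit of > 100000 nM in this assay, at which 2 of the 3 values shown sit.

Going by these compounds, whether this effect is specific to ethynyl remains open, since bromo, methyl or a longer chain such as propynyl at the same place would be needed to show it. On these data alone, whether ethynyl would have the same effect on the core of compound 1 also remains open.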